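Removing tert-butoxycarbonyl from compound 2

The compounds below may be only part of what the source reports. "The series", "measured", "known", "first", "only" and "open" are said of these compounds alone.

In a functional assay on MCF7 cells (Homo sapiens) for cytotoxicity, read by MTT assay (a higher number here means a weaker inhibitor, a lower number a stronger inhibitor), compound 1 `COCOc1cc(C2CC2c2cc(OC)c(OC)c(OC)c2)ccc1OC` gives 14000 nM and compound 2 `COc1ccc(C2CC2c2cc(OC)c(OC)c(OC)c2)cc1NC(=O)OC(C)(C)C` gives 11800 nM so the two stand level within the scatter. The change hydrogen in place of tert-butoxycarbonyl on a nitrogen on an aromatic ring leads from compound 2 to compound 3 `COc1ccc(C2CC2c2cc(OC)c(OC)c(OC)c2)cc1N` with hydrogen in place of tert-butoxycarbonyl on a nitrogen on an aromatic ring. Within the data shown here, the only measured step of a 1.2-fold lower number from compound 1 to compound 2 (0.07 log units; within the scatter) exchanged methoxymethoxy for (tert-butoxycarbonyl)amino and does not test the bare amino. The expected shift in this assay is therefore modest and toward a lower number, estimated as a 2.4-fold lower number from compound 2 to compound 3 (0.37 log units; beyond the scatter) with wide uncertainty. Compound 3 is expected at 5000 nM (800 nM to 20000 nM).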

Compound 3, half-maximal inhibitory concentration: 212 nM
Compound 3: the middle estimate sits 24-fold (1.37 log units) above what was measured; the measured number lies below the stated range.
By their numbers in this assay, from the lowest: compound 3; then compounds 2 and 1 (each within the scatter of the next).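

In this assay, this position proves highly sensitive once the nitrogen is left bare: hydrogen in place of tert-butoxycarbonyl gives a 56-fold lower number from compound 2 to compound 3 (1.75 log units; beyond the scatter), and amino in place of methoxymethoxy gives a 66-fold lower number from compound 1 to compound 3 (1.82 log units; beyond the scatter). Methoxymethoxy and (tert-butoxycarbonyl)amino had stood level within the scatter, so the earlier pair gave no sign that a change here could move the number this far. Nothing available explains the size of this drop.

On these data alone, it remains open how a hydroxyl, an acetamide or a dimethylamino group on this aromatic carbon would read in this assay, and so whether the low number is particular to the amino group.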